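The source may report more compounds than this note shows. Statements on the series, on what has been measured and on what is new or still open speak of the compounds shown alone.

Measured in a physicochemical assay for lipophilicity, read by HPLC; a lower number here means a more polar compound, a higher number a more lipophilic compound:

- compound 1 `Cc1ccsc1C(=CCCN(C)C(CC(C)O)C(=O)NCc1ccc(F)cc1)c1sccc1C` gives 5.51
- compound 2 `Cc1ccsc1C(=CCCN(C)C(CC(C)O)C(=O)NCc1ccc(Cl)cc1)c1sccc1C` gives 5.99; 6.77 (2 entries)
- compound 3 `Cc1ccsc1C(=CCCN(C)C(CC(C)O)C(=O)NCc1ccccc1)c1sccc1C` gives 5.64; 6.22 (2 entries)

All three share one core and differ only in the group carried on the benzyl amide. Compound 1 is the only one of them with a single number in this assay; compound 2 has several entries (the several entries of compound 2 in this assay, 5.99; 6.77 (2 entries)), as does compound 3 (the several entries of compound 3 in this assay, 5.64; 6.22 (2 entries)), and in both cases the entries spread over more than the usual scatter. Compound 1 gives the lowest single number in the set, though it sits close to one of the entries of compound 3, so no firm order among the three can be drawn from these numbers.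

Compound 4 `Cc1ccsc1C(=CCCN(C)C(CCO)C(=O)NCc1ccc(F)cc1)c1sccc1C` has not yet been measured. It differs from compound 1 in one place: hydrogen in place of methyl on a saturated chain carbon bound to an oxygen on a saturated carbon and a saturated chain carbon. For the measured compounds named here, no step of this kind between measured compounds is at hand, so the expectation rests on the change alone. Compound 4 is expected to come out a little more polar than compound 1, by a step of a number 0.41 log units lower from compound 1 to compound 4 (beyond the scatter) that is estimated to reach just beyond the scatter, giving an expected value of 5.1, with a range from 4.6 to 5.6.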

Compound 4, partition coefficient: 5.87
Compound 4: middle estimate off by 0.77 log units, on the low side; the measured number lies above the stated range.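

Replacing the methyl with hydrogen, which turns 2-hydroxypropyl into 2-hydroxyethyl, gives a number 0.36 log units higher from compound 1 to compound 4 (beyond the scatter) in this assay. At this position, then, one carbon fewer does not bring a lower number, at least in this single pair. The step is modest and rests on one pair, and repeated entries on the same core can spread further than this step: the several entries of compound 2 in this assay, 5.99; 6.77 (2 entries)

As far as these compounds go, it remains open whether the same change would move the number in the same direction on the benzyl amides of compound 2 and compound 3, whose own entries would make any such step harder to read. Also open, from the compounds shown here alone, is what a longer chain, or an amine in place of the hydroxyl on this chain, would give.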